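Swapping a phenyl for hydroxy in a cytotoxicity series

The source may hold more compounds than are shown below. What is called first, only, known or untested is meant among the compounds shown, and "the series" means these compounds.

Of the compounds shown here, three have so far been tested in an ADME assay on HCT-116 cells (Homo sapiens) for cytotoxicity, read by CellTiter-Glo, with a stated time of 72 h; on this read-out lower numbers stand for stronger inhibition and higher numbers for weaker inhibition. Compound 1, `Cc1cc(C)c(S(=O)(=O)N2CCC(N3CCC(c4ccccc4)CC3)CC2)c(C)c1`, gives > 5000 nM, which is a limit of the assay rather than a measured number. Compound 2, `CC1CCN(C2CCN(S(=O)(=O)c3cccc(-c4ccc(F)cc4)c3)CC2)CC1`, likewise gives > 5000 nM, again a limit. Compound 3, `COc1ccc(NS(=O)(=O)N2CCC(N3CCC(C)CC3)CC2)cc1`, gives > 5000 nM, once more a limit. Compound 1 therefore stands exactly where its two companions stand: the limit of > 5000 nM in this assay, at which 3 of the 3 values shown sit. Going by the values given here, no compound in this set has yet produced a numerical reading in this assay, so there is no measured step between any two of them to draw on.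

Compound 4, `Cc1cc(C)c(S(=O)(=O)N2CCC(N3CCC(O)CC3)CC2)c(C)c1`, is the next compound to be tested. It differs from compound 1 in one place: hydroxy in place of phenyl on a saturated ring carbon. The rest of the shared core of compound 1 is kept unchanged.

With every measured value sitting at the limit, the step is expected to be none beyond the scatter, a step that the limit leaves unreadable from compound 1 to compound 4. Compound 4 is accordingly expected to give about 8000 nM, with a range from 3000 nM to 30000 nM, and the most likely outcome is that the assay again reports only a limit for it.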

Compound 4, half-maximal inhibitory concentration: > 5000 nM
Compound 4: only a limit was reported (the forecaster's own chance of this, stated with the estimate: 80%); the middle value lies beyond the limit too.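

Going by these compounds alone, compound 1 and compound 4 both end at a limit rather than a measured number, so hydroxy in place of phenyl gives no step that can be read, and the set stays where it was: the limit of > 5000 nM in this assay, at which 4 of the 4 values shown sit.

From the compounds shown here alone, what stays open is how far past that limit each compound lies, and so whether this swap changes anything in this assay.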